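Replacing the arylamine with azetidine in the series

The source may hold more compounds than are shown below. What is called first, only, known or untested is meant among the compounds shown, and "the series" means these compounds.

Three compounds of the series have been run in a functional assay on MCF7 cells (Homo sapiens) for inhibition, read by sulforhodamine B assay; a lower number here means a stronger inhibitor, a higher number a weaker inhibitor. Compound 1 `O=C1C=C(Nc2ccc(I)cc2)C(=O)c2c1nc1n2[C@H]2OC[C@@H](O)[C@H]2OC1` gives 2230 nM in this assay. Compound 2 `O=C1C(Nc2cccc(Cl)c2)=CC(=O)c2c1nc1n2[C@H]2OC[C@@H](O)[C@H]2OC1` gives 2970 nM in this assay. For compound 3 `COc1cccc(NC2=CC(=O)c3nc4n(c3C2=O)[C@H]2OC[C@@H](O)[C@H]2OC4)c1` this assay reports only a limit, > 4000 nM. Among the compounds with values here, the one single-point step among the measured compounds, an at least 1.7-fold higher number from compound 1 to compound 3 (0.25 log units; that floor lies within the scatter), therefore rests on that limit of > 4000 nM in this assay, at which 1 of the 3 values shown sits, and sets only a floor. Of the two real numbers, compound 2 holds the higher one, and its nearest neighbour is compound 1, a gap that falls within the usual scatter, so no order between them can be read.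

Compound 4 `O=C1C(N2CCC2)=CC(=O)c2c1nc1n2[C@H]2OC[C@@H](O)[C@H]2OC1` differs from compound 2 in one place: azetidin-1-yl in place of (3-chlorophenyl)amino on a double-bonded ring carbon. Within the data shown here, none of the measured steps bears directly on this change; the step from compound 1 to compound 3 swaps one aryl group for another on the amine nitrogen and leaves the arylamino motif intact, whereas here the whole aryl amine is removed in favour of a small saturated ring. Every measured compound carries an aryl-substituted amine, so the series gives no anchor for the direction of the change. Compound 4 is therefore expected to land near the number of compound 2, with wide uncertainty in both directions, and a limit cannot be excluded. The step of a 1.2-fold higher number from compound 2 to compound 4 (0.07 log units; within the scatter) is expected to stay within the scatter. Compound 4 is estimated at 3500 nM, with a range from 1500 nM to 9000 nM.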

Compound 4, half-maximal inhibitory concentration: > 16000 nM
Compound 4 ended at the assay's limit; the forecaster's own chance of this, stated with the estimate: 45%; middle value at least 4.5-fold (0.66 log units) away from the limit.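

In this assay compound 4 gives > 16000 nM, which is a limit and not a number. Within the data shown here, the step, an at least 5.3-fold higher number from compound 2 to compound 4 (0.73 log units; beyond the scatter), is the first to lie beyond the scatter: on this double-bonded ring carbon, azetidin-1-yl does not hold the level of (3-chlorophenyl)amino, whereas the earlier step only exchanged one aryl group for another on the amine nitrogen and kept the arylamino motif. The size of the new step is only a floor because it rests on a limit: the limit of > 16000 nM in this assay, at which 1 of the 4 values shown sits.

The change removes the six-membered aromatic ring and the hydrogen-bond donor together, so the compounds shown cannot tell which of the two matters, or whether the smaller group or the four-membered ring itself accounts for the step. A cyclohexylamino group would keep the amine hydrogen without the aromatic ring, a methyl(3-chlorophenyl)amino group would keep the aromatic ring without that hydrogen, and a piperidine would test a larger saturated ring at this position.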